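Melanoma growth inhibition: aryl variants on the carbonyl linker

This account rests on a few compounds, and the source may have more. Where it says the series, first, only, none or still open, it means among the compounds named here.

Measured compounds:
compound 1 `COc1cc(-c2nn(-c3cccc(NC(=O)Nc4ccc(Cl)c(Cl)c4)c3)cc2-c2ccncc2)ccc1Cl`: 1040 nM
compound 2 `COc1cc(-c2nn(-c3cccc(NC(=O)Nc4cccc(C(F)(F)F)c4)c3)cc2-c2ccncc2)ccc1Cl`: 923 nM

In a functional assay on UACC-257 cells (Homo sapiens) for inhibition, read by sulforhodamine B assay, with a stated time of 48 h (on this read-out higher numbers stand for weaker inhibition of growth and lower numbers for stronger inhibition of growth), compound 2 gives 923 nM, the lowest of the two numbers shown. Its nearest neighbour is compound 1, and the step between them, a 1.1-fold lower number from compound 1 to compound 2 (0.05 log units; within the scatter), lies within the scatter, so no order between compound 1 and compound 2 can be read from these two values.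

Compound 3 `COc1cc(-c2nn(-c3cccc(NC(=O)c4ccccc4)c3)cc2-c2ccncc2)ccc1Cl` is not yet measured. It differs from compound 2 as follows: phenyl in place of (3-(trifluoromethyl)phenyl)amino on a carbonyl carbon. Among the measured compounds shown here, the one measured step, a 1.1-fold lower number from compound 1 to compound 2 (0.05 log units; within the scatter), only swaps the aryl on the amide-type nitrogen and keeps the (aryl)amino group on the carbonyl carbon; it does not bear on removing that group together with its hydrogen-bond donor. For the measured compounds named here, no measured pair tests this change, so the expectation rests on the structural change alone.

The step expected from compound 2 to compound 3 is a 2.0-fold higher number from compound 2 to compound 3 (0.29 log units; within the scatter), toward weaker inhibition, with a wide range. Compound 3 is estimated at 1800 nM, between 500 nM and 6500 nM.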

Compound 3, concentration for 50% growth inhibition: 859 nM
For compound 3 the middle estimate is 2.1-fold (0.32 log units) above the measured one; low and high end bracket the measured number.
By their numbers in this assay, from the lowest: compounds 3, 2 and 1 (each within the scatter of the next).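

In this assay, phenyl in place of (3-(trifluoromethyl)phenyl)amino on a carbonyl carbon gives a 1.1-fold lower number from compound 2 to compound 3 (0.03 log units; within the scatter), and phenyl in place of (3,4-dichlorophenyl)amino gives a 1.2-fold lower number from compound 1 to compound 3 (0.08 log units; within the scatter). The earlier pair kept the (aryl)amino group throughout, whereas these steps remove its nitrogen and hydrogen-bond donor and leave no readable difference in growth inhibition among these compounds. No supporting measurement bears on this result.

On these data alone, whether a morpholine or a longer alkyl chain on the carbonyl carbon would keep the numbers in this range stays open. Also open, as far as these compounds go, is whether a carboxylic acid or an amine on the phenyl of compound 3 would separate it from compound 1 and compound 2 by more than the scatter.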